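Series notes: chloro in place of nitro, toward compound 4

A few compounds are considered here, and "the series" means these few. Any claim that something is new, unique, unknown or untested is made for them only; others in the source may bear on it.

Among the measured compounds shown here, compound 1 `CC(C)n1c(/C=C2/C(=O)Nc3ccccc32)nc2ccccc21` is the only member with a number: in a functional assay on MDA-MB-231 cells (Homo sapiens) for cytotoxicity, read by MTT assay, with a stated time of 48 h (on this read-out higher numbers stand for weaker inhibition and lower numbers for stronger inhibition), compound 1 gives 30400 nM. Compound 2 `Cn1c(/C=C2/C(=O)Nc3ccc([N+](=O)[O-])cc32)nc2ccccc21` has no number; in this assay compound 2 gives "not determined" (no result reported). Compound 3 `CCn1c(/C=C2/C(=O)Nc3ccc([N+](=O)[O-])cc32)nc2ccccc21` stands the same way, since in this assay compound 3 gives "not determined" (no result reported). Compound 2 therefore stands nowhere on the numbers shown, and one further entry is equally without a number. Compound 4 `Cn1c(/C=C2/C(=O)Nc3ccc(Cl)cc32)nc2ccccc21` differs from compound 2 by chloro in place of nitro on an aromatic carbon. For the measured compounds named here, no measured step exists between any two compounds, so no direction beyond the scatter is expected for this change in this assay; the only anchor is compound 1 at 30400 nM. For compound 4 the expected value is 20000 nM, with a range from 5000 nM to 80000 nM.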

Compound 4, half-maximal inhibitory concentration: 37600 nM
Beside the measured number, compound 4's estimate is 1.9-fold (0.27 log units) below it, within the range that was stated.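

No new step can be read from compound 4, since its one-place partner, compound 2, has no single number, and no evidence bears on the result. From the compounds shown here alone, what chloro in place of nitro does to the read-out stays open.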